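The source may hold more compounds than are shown below. What is called first, only, known or untested is meant among the compounds shown, and "the series" means these compounds.

In a functional assay on MCF7 cells (Homo sapiens) for inhibition, read by resazurin assay, with a stated time of 72 h (on this read-out lower numbers stand for stronger inhibition and higher numbers for weaker inhibition), compound 1 `COc1cc(N2C(=O)CC2c2ccc(SC)cc2)cc(OC)c1OC` gives 67 nM and compound 3 `COc1ccc(C2C(Oc3ccccc3)C(=O)N2c2cc(OC)c(OC)c(OC)c2)cc1` gives 23 nM. Compound 2 `COc1ccc(C2C(O)C(=O)N2c2cc(OC)c(OC)c(OC)c2)cc1O` gives 3 nM, the lowest of the three numbers, and its gaps to both other compounds lie beyond the scatter. Compound 4 `COc1cc(N2C(=O)C(O)C2c2ccc(SC)cc2)cc(OC)c1OC` has not yet been measured. It keeps the hydroxy group of compound 2 on the four-membered ring, but 4-(methylsulfanyl)phenyl replaces 3-hydroxy-4-methoxyphenyl on a saturated ring carbon: 4-(methylsulfanyl)phenyl in place of 3-hydroxy-4-methoxyphenyl on a saturated ring carbon. Among the compounds with values here, no measured pair isolates this change, so any forecast rests on indirect evidence. Compound 1 carries the same 4-(methylsulfanyl)phenyl group without the ring hydroxy group and gives 67 nM, a number that suggests compound 4 will remain fairly potent but probably will not match compound 2. The expected change is a 5.0-fold higher number from compound 2 to compound 4 (0.70 log units; beyond the scatter), towards weaker inhibition and probably beyond the scatter. For compound 4 the estimate is 15 nM, with an expected range from 4 nM to 60 nM.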

Compound 4, half-maximal inhibitory concentration: 5 nM
Compound 4: the middle estimate sits 3.0-fold (0.48 log units) above what was measured, within the range that was stated.
By their numbers in this assay, from the lowest: compounds 2 and 4 (each within the scatter of the next); then compound 3; then compound 1.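

In this assay, 4-(methylsulfanyl)phenyl in place of 3-hydroxy-4-methoxyphenyl gives a 1.7-fold higher number from compound 2 to compound 4 (0.22 log units; within the scatter), so with the hydroxy group present on the four-membered ring, the two aryl groups cannot be told apart at this position. Hydroxy in place of hydrogen on the saturated ring carbon gives a 13-fold lower number from compound 1 to compound 4 (1.13 log units; beyond the scatter), showing directly that this small addition matters greatly when 4-(methylsulfanyl)phenyl is present. No supporting measurement bears on why the numbers fall this way.

The compounds shown leave open whether the hydroxy step would be as large with other aryl groups on the neighbouring ring carbon. They also leave open whether an amine or a fluorine atom could stand in for the hydroxy group on the four-membered ring.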